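Dropping the Fluorine from Compound 3's Aryl Group

A few compounds are considered here, and "the series" means these few. Any claim that something is new, unique, unknown or untested is made for them only; others in the source may bear on it.

Of the compounds shown here, three with a shared core have been measured in an ADME assay for permeability, using PAMPA, with a stated time of 30 min, at pH 7.4; on this read-out lower numbers stand for lower permeability and higher numbers for higher permeability. Compound 1 `COc1ccc(F)cc1CNCCCNc1ccnc2cc(CCc3ccccc3)ccc12` gives 23 10^-6 cm/s. Compound 2 `COc1cccc(CNCCCNc2ccnc3cc(-c4ccccc4)ccc23)c1O` gives 237 10^-6 cm/s, and compound 3 `COc1ccc(F)cc1CNCCCNc1ccnc2cc(-c3ccc(F)cc3)ccc12` gives 237 10^-6 cm/s. Compound 3 therefore stands level with compound 2 at the digits shown, and the single measured step, a 10-fold higher number from compound 1 to compound 3 (1.01 log units; beyond the scatter), places it well above compound 1.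

Compound 4 `COc1ccc(F)cc1CNCCCNc1ccnc2cc(-c3ccccc3)ccc12` is the next compound. It differs from compound 3 in one place: hydrogen in place of fluoro on an aromatic carbon. Within the data shown here, no measured step covers this exact change. Among the measured compounds shown here, the only step seen, from compound 1 to compound 3, concerns a different part of the molecule and cannot be carried over. Compound 2, which carries a phenyl group in the same position as compound 4, gives the same number as compound 3, but it also differs elsewhere, so only the two values themselves can be compared.

On this basis the expected step of a 1.0-fold lower number from compound 3 to compound 4 (0.01 log units; within the scatter) is none beyond the scatter. Compound 4 is estimated at 230 10^-6 cm/s, in the range 120 10^-6 cm/s to 400 10^-6 cm/s.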

Compound 4, apparent permeability in the ADME assay: 237 10^-6 cm/s
Compound 4: middle estimate off by 1.0-fold (0.01 log units), on the low side, and the stated range covers the measured number.
By their numbers in the ADME assay, from the lowest: compound 1; then compounds 2, 3 and 4 (each within the scatter of the next).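

In the ADME assay, hydrogen in place of fluoro on this aromatic carbon leaves the read-out unmoved (no change at the digits printed from compound 3 to compound 4 (within the scatter)), and in a physicochemical assay for acid dissociation, compound 3 (9.47) and compound 4 (9.47) also stand level (no change at the digits printed from compound 3 to compound 4 (within the scatter)). Back in the ADME assay, 5-fluoro-2-methoxyphenyl in place of 2-hydroxy-3-methoxyphenyl shows no separation either (no change at the digits printed from compound 2 to compound 4 (within the scatter)), while phenyl in place of phenethyl gives a large step (a 10-fold higher number from compound 1 to compound 4 (1.01 log units; beyond the scatter)), so among these compounds only the phenethyl change shifts the number. Nothing available explains why the fluorine makes no measurable difference here.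

On these data alone, whether a larger or charged group at this spot, such as an amine or a carboxylic acid, would also leave both read-outs level remains open. A single fluorine-to-hydrogen swap cannot show how far this tolerance extends.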